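Chlorophenyl Swap on a Shorter Chain: An Anticonvulsant Estimate

The source may report more compounds than this note shows. Statements on the series, on what has been measured and on what is new or still open speak of the compounds shown alone.

Compound 1, `CCC(C(=O)N1CCN(c2ccccc2Cl)CC1)N1C(=O)CCC1=O`: 25%
Compound 2, `CCC(C(=O)N1CCN(c2cccc(F)c2)CC1)N1C(=O)CCC1=O`: 100%
Compound 3, `CC(C(=O)N1CCN(c2cccc(F)c2)CC1)N1C(=O)CCC1=O`: 50%

The three were tested in a functional assay on the whole organism (strain Swiss) with Mus musculus as the target, in the maximal electroshock model, with a stated time of 0.5 h, at a dose of 300 mg/kg by the intraperitoneal route; on this read-out lower numbers stand for a weaker effect and higher numbers for a stronger effect at the one dose given. Compound 3 differs from compound 2 in one place, (hydrogen in place of methyl on a saturated chain carbon, two bonds along the chain from an amide-type nitrogen in a ring and a carbonyl carbon), and that step gives a number 50 percentage points lower from compound 2 to compound 3 (beyond the scatter). Compound 1 differs from compound 2 by 2-chlorophenyl in place of 3-fluorophenyl on an amine nitrogen in a ring, a step of a number 75 percentage points lower from compound 2 to compound 1 (beyond the scatter). Compound 4, `CC(C(=O)N1CCN(c2ccccc2Cl)CC1)N1C(=O)CCC1=O`, is not yet measured; it differs from compound 3 by 2-chlorophenyl in place of 3-fluorophenyl on an amine nitrogen in a ring, the same change that was made from compound 2 to compound 1 with a step of a number 75 percentage points lower from compound 2 to compound 1 (beyond the scatter). Because compound 3 already stands at 50%, a fall of that kind is expected to bring the number down to a small value. In this assay compound 4 is therefore expected to show a number 40 percentage points lower from compound 3 to compound 4 (beyond the scatter). The estimate for compound 4 is 10%, with a range from 0% to 40%.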

Compound 4, a percentage reported as activity, at one dose (the size of the read-out at that dose, not a potency): 0%
For compound 4 the middle estimate is 10 percentage points above the measured one, within the range that was stated.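

In this assay the change to 2-chlorophenyl in place of 3-fluorophenyl lowers the number on both cores, here by a number 50 percentage points lower from compound 3 to compound 4 (beyond the scatter), but its size does not carry over unchanged: the same change on two cores in this assay, a number 75 percentage points lower (beyond the scatter) from compound 2 to compound 1 and a number 50 percentage points lower (beyond the scatter) from compound 3 to compound 4, 25 percentage points apart, beyond the scatter of two such steps.

Hydrogen in place of methyl likewise keeps its direction, with a number 25 percentage points lower from compound 1 to compound 4 (beyond the scatter), and again differs in size: the same change on two cores in this assay, a number 50 percentage points lower (beyond the scatter) from compound 2 to compound 3 and a number 25 percentage points lower (beyond the scatter) from compound 1 to compound 4, 25 percentage points apart, beyond the scatter of two such steps.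

Compound 4 stands at 0% and the read-out ends there, so these steps do not show how far the number might otherwise have fallen, and a single dose gives no measure of potency.

The compounds shown leave open how a plain phenyl, a 2-fluorophenyl or a 3-chlorophenyl would behave on either core. They also leave open what a longer chain would do at the carbon that carries the methyl.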